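Swapping the aryl group on a hydroxy-linked triazole lactone

The compounds below may be only part of what the source reports. "The series", "measured", "known", "first", "only" and "open" are said of these compounds alone.

The compounds here were tested in a functional assay on A549 cells (Homo sapiens) for antiproliferative activity, read by MTT assay, with a stated time of 72 h; a higher number here means a weaker inhibitor, a lower number a stronger inhibitor. Compound 1 `Cc1ccc(-c2cn(C/C=C3\OC(=O)C(OCc4ccccc4)=C3OCc3ccccc3)nn2)cc1` shows only a limit in this assay, giving > 100000 nM. Compound 2 `O=C1O/C(=C\Cn2cc(-c3cc(F)cc(F)c3)nn2)C(OCc2ccccc2)=C1OCc1ccccc1` likewise shows only a limit in this assay, giving > 100000 nM. The change between them is 3,5-difluorophenyl in place of 4-methylphenyl on an aromatic carbon, and the step it made, a step that the two limits leave unreadable from compound 1 to compound 2, cannot be read because of the limit of > 100000 nM in this assay, at which 2 of the 3 values shown sit. For the measured compounds named here, compound 3 `Cc1ccc(-c2cn(C[C@H](O)[C@H]3OC(=O)C(OCc4ccccc4)=C3OCc3ccccc3)nn2)cc1` carries a different linker between the triazole and the lactone, and in this assay compound 3 gives 8690 nM, the one clear number in the set. The difference between the core of compound 1 and the core of compound 3 is not broken down here.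

Compound 4 `O=C1O[C@H]([C@@H](O)Cn2cc(-c3cc(F)cc(F)c3)nn2)C(OCc2ccccc2)=C1OCc1ccccc1` has not yet been measured. It differs from compound 3 by 3,5-difluorophenyl in place of 4-methylphenyl on an aromatic carbon, the same change already seen between compound 1 and compound 2, at the same place. Since that earlier step was left unreadable by the two limits, the expected step from compound 3 to compound 4 is a modest one, a 1.2-fold higher number from compound 3 to compound 4 (0.06 log units; within the scatter). Compound 4 is therefore expected to give about 10000 nM in this assay, plausibly between 3000 nM and 35000 nM.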

Compound 4, half-maximal inhibitory concentration: 41200 nM
The estimate for compound 4 lay 4.1-fold (0.61 log units) below the measured number; the whole stated range lies below it.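

In this assay, putting 3,5-difluorophenyl in place of 4-methylphenyl on the hydroxy-linked core gave a 4.7-fold higher number from compound 3 to compound 4 (0.68 log units; beyond the scatter), so on this core the change goes with a weaker inhibitor. The same change on the core of compound 1 gives no size to compare with, because both compounds of that pair sit at the limit of the assay, and a limit is not a number: the limit of > 100000 nM in this assay, at which 2 of the 4 values shown sit. The series therefore gives one readable size for this change, on one core only, and it does not show whether the change carries over from one core to the other or why the number rose.

Still open, as far as these compounds go, is how the number would move with a plain phenyl, an amine or a carboxylic acid in place of these aryl groups, on the same aromatic carbon. Also open, from the compounds shown here alone, is what a longer chain in the linker would do with either aryl group.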